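From 4-nitrophenyl to 3-fluorophenyl on a shared core

This account rests on a few compounds, and the source may have more. Where it says the series, first, only, none or still open, it means among the compounds named here.

Among the measured compounds shown here, in a physicochemical assay for lipophilicity, read by LC-MS, using the shake flask method, in phosphate buffer, measured as octanol-water partition, with a stated time of 2 h, at pH 7.4 (on this read-out higher numbers stand for higher lipophilicity and lower numbers for lower lipophilicity), only one number anchors this small series. Compound 1 (`O=C(O)c1ccc(-n2cc(CO[C@H]3O[C@H](CO)[C@@H](O)[C@H](O)[C@@H]3O)nn2)cc1`) is recorded as "not determined" (no result reported) and so offers no comparison. Compound 2 (`O=[N+]([O-])c1ccc(-n2cc(CO[C@H]3O[C@H](CO)[C@@H](O)[C@H](O)[C@@H]3O)nn2)cc1`) gives -0.16 and stands alone, with no other number to rank it against. Compound 3 (`OC[C@H]1O[C@H](OCc2cn(-c3cccc(F)c3)nn2)[C@@H](O)[C@@H](O)[C@@H]1O`) keeps the shared core but carries 3-fluorophenyl in place of 4-nitrophenyl on an aromatic nitrogen. For the measured compounds named here, no measured pair here shows what such an exchange does, so the expectation rests on the structural change alone and remains loose. A modest rise in this assay is expected, with a number 0.31 log units higher from compound 2 to compound 3 (beyond the scatter) as the estimated step. For compound 3 the estimated value is 0.15 with -0.2 to 0.5 as the expected range.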

Compound 3, distribution coefficient: 0.18
For compound 3 the middle estimate is 0.03 log units below the measured one; low and high end bracket the measured number.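

Replacing 4-nitrophenyl with 3-fluorophenyl gives this series its first measured step, and in this assay it is a number 0.34 log units higher from compound 2 to compound 3 (beyond the scatter). This shows that the value on this read-out shifts when one substituted phenyl group on the aromatic nitrogen is exchanged for another while the shared core stays the same. No supporting measurement bears on why the number moves.

Since the group and the place of its substituent on the phenyl ring both differ, this single step cannot show how much each contributes, and 4-fluorophenyl on the same nitrogen would be the natural comparison with compound 3. Going by these compounds, how an amine on that phenyl ring, or a longer chain such as 4-propylphenyl, would compare with compound 2 and compound 3 also remains open.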